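Swapping the Aryl Group on a Shared Core

A few compounds are considered here, and "the series" means these few. Any claim that something is new, unique, unknown or untested is made for them only; others in the source may bear on it.

Compound 2 `CCOc1ccc(Nc2nc(SCc3ccc(C(F)(F)F)cc3)nc3ccccc23)cc1` and compound 1 `O=[N+]([O-])c1cccc(Nc2nc(SCc3ccc(C(F)(F)F)cc3)nc3ccccc23)c1` share one core and differ only in the group on a nitrogen on an aromatic ring. In a functional assay on MDA-MB-231 cells (Homo sapiens) for cytotoxicity, read by MTT assay, with a stated time of 72 h (on this read-out lower numbers stand for stronger inhibition and higher numbers for weaker inhibition), compound 1 gives 31500 nM, and compound 2 gives 23000 nM. Compound 2 holds the lower of the two numbers, yet the two cannot be told apart, since the step of a 1.4-fold lower number from compound 1 to compound 2 (0.14 log units; within the scatter) is within the scatter. Compound 3 `Fc1ccc(Nc2nc(SCc3ccc(C(F)(F)F)cc3)nc3ccccc23)cc1Cl` carries the change (3-chloro-4-fluorophenyl in place of 4-ethoxyphenyl on a nitrogen on an aromatic ring). Going by the values given here, only that one measured step, an exchange of the group at the same place, bears on this change, and it stayed within the scatter. A further exchange at the same place is therefore expected to move the number little in either direction. Compound 3 is estimated at 25000 nM, with a range from 8000 nM to 80000 nM. That estimate means an expected step of a 1.1-fold higher number from compound 2 to compound 3 (0.04 log units; within the scatter), none beyond the scatter.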

Compound 3, half-maximal inhibitory concentration: 14500 nM
Compound 3: middle estimate off by 1.7-fold (0.24 log units), on the high side; low and high end bracket the measured number.
By their numbers in this assay, from the lowest: compounds 3, 2 and 1 (each within the scatter of the next, the first and the last beyond it).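

In this assay, going by these compounds alone, the 3-chloro-4-fluorophenyl group on this nitrogen gives the first step at this position that clears the scatter: a 2.2-fold lower number from compound 1 to compound 3 (0.34 log units; beyond the scatter), a modest move away from the 3-nitrophenyl group. Against the 4-ethoxyphenyl group, the same exchange gives a 1.6-fold lower number from compound 2 to compound 3 (0.20 log units; within the scatter), so compound 2 still cannot be told apart from either of the other two compounds. Nothing measured here explains the difference, which stands only as an observation.

As far as these compounds go, all three groups are substituted phenyl rings, so it remains open how the number responds at this position to a simple alkyl chain, a morpholine or a carboxylic acid. It is also unclear whether the chlorine, the fluorine or both account for the step; a 3-chlorophenyl or a 4-fluorophenyl group would separate them.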